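Cytotoxicity notes on the amine series, compound 4

This account rests on a few compounds, and the source may have more. Where it says the series, first, only, none or still open, it means among the compounds named here.

Within the data shown here, compound 1 `COCOc1ccc(CN(Cc2ccc(C(C)(C)C)cc2)Cc2cc3cc(C)ccc3[nH]c2=O)cc1` is the one member with a read number: in a toxicity assay on MDCK cells (Canis lupus familiaris) for cytotoxicity, read by crystal violet staining, with a stated time of 48 h (on this read-out higher numbers stand for lower toxicity in this test and lower numbers for higher toxicity in this test), compound 1 gives 6400 nM. Compound 2 `Cc1ccc2[nH]c(=O)c(CN(Cc3ccc(C(C)(C)C)cc3)[C@H](C)c3ccc(F)cc3)cc2c1` reaches only a limit of the test, and in this assay compound 2 gives > 5000 nM. Compound 3 `Cc1ccc2[nH]c(=O)c(CN(Cc3ccc(C(C)(C)C)cc3)C(C)c3ccc(OC(F)F)cc3)cc2c1` likewise stops at a limit, and in this assay compound 3 gives > 5000 nM. Compound 3 therefore stands at the limit of the test, not at a number. The steps a step that the limit leaves unreadable from compound 1 to compound 2 and a step that the limit leaves unreadable from compound 1 to compound 3 cannot be sized, and neither can a step that the two limits leave unreadable from compound 2 to compound 3; this follows from the limit of > 5000 nM in this assay, at which 2 of the 3 values shown sit.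

Compound 4 `Cc1ccc2[nH]c(=O)c(CN(Cc3ccc(C(C)(C)C)cc3)C(C)c3ccc(N(C)C)c(Cl)c3)cc2c1` differs from compound 3 by 3-chloro-4-(dimethylamino)phenyl in place of 4-(difluoromethoxy)phenyl on a saturated chain carbon bound to an amine nitrogen and a saturated chain carbon. Among the measured compounds shown here, none of the measured steps covers this exchange, and each of them is unreadable, so no measured step supplies a size or a direction for it. The expectation for compound 4 is accordingly no step beyond the scatter, that is a step that the limit leaves unreadable from compound 3 to compound 4, with a strong chance that the test again reports only its limit rather than a number. Compound 4 is estimated in this assay at 8000 nM, within a range of 3000 nM to 30000 nM.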

Compound 4, half-maximal cytotoxic concentration: 9800 nM
For compound 4 the middle estimate is 1.2-fold (0.09 log units) below the measured one, within the range that was stated.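

Among these compounds, with compound 4, this assay gives a read number for a 1-arylethyl group on the amine nitrogen, so this kind of group can for the first time be set against the 4-(methoxymethoxy)benzyl group of compound 1. The exchange of that benzyl group for 1-(3-chloro-4-(dimethylamino)phenyl)ethyl is a 1.5-fold higher number from compound 1 to compound 4 (0.19 log units; within the scatter), which means that on this evidence the two groups cannot be told apart in this read-out. The steps to compound 4 from compound 2 and from compound 3 still cannot be read, because those two compounds stop at a limit and not at a number: the limit of > 5000 nM in this assay, at which 2 of the 4 values shown sit.

The separate contributions of the chloro and dimethylamino parts of the new group stay open among the compounds shown. Also open, from the compounds shown here alone, is how the same position would read with a carboxylic acid or a nitrile on its phenyl ring, and whether any group there would bring the read-out clear of the scatter around compound 1.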